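Swapping the aryl group on the imine of a pyrazolone core

The source may report more compounds than this note shows. Statements on the series, on what has been measured and on what is new or still open speak of the compounds shown alone.

Measured compounds:
compound 1 `Cc1c(/N=C/c2ccccc2Cl)c(=O)n(-c2ccccc2)n1C` — 309000000 nM
compound 2 `COc1cccc(/C=N/c2c(C)n(C)n(-c3ccccc3)c2=O)c1` — 155000000 nM
compound 3 `COc1ccccc1/C=N/c1c(C)n(C)n(-c2ccccc2)c1=O` — 70800000 nM

In a functional assay on HT-29 cells (Homo sapiens) for cytotoxicity, read by MTT assay, with a stated time of 72 h (a lower number here means a stronger inhibitor, a higher number a weaker inhibitor), compound 3 gives the lowest number of the three, and both gaps to it lie beyond the scatter, so it is the most potent of these compounds. Compound 4 `Cc1c(/N=C/c2ccc(Cl)cc2)c(=O)n(-c2ccccc2)n1C` is not yet measured; it differs by 4-chlorophenyl in place of 2-methoxyphenyl on a carbon with a double bond to nitrogen. Among the compounds with values here, two measured steps bear on this. Replacing chloro by methoxy gave a 4.4-fold lower number from compound 1 to compound 3 (0.64 log units; beyond the scatter), and moving methoxy between ring positions gave a 2.2-fold lower number from compound 2 to compound 3 (0.34 log units; beyond the scatter). Compound 4 reverses the first change and also relocates the substituent, so a higher number, in the range of compound 1, is expected: a 3.5-fold higher number from compound 3 to compound 4 (0.55 log units; beyond the scatter). The estimate for compound 4 is 250000000 nM, expected between 100000000 nM and 600000000 nM.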

Compound 4, half-maximal inhibitory concentration: 309000000 nM
Estimate against measurement, compound 4: 1.2-fold (0.09 log units) below; low and high end bracket the measured number.
By their numbers in this assay, from the lowest: compound 3; then compounds 2, 1 and 4 (each within the scatter of the next).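

In this assay the chloro group can sit on either ring place tested here without a visible effect: 4-chlorophenyl in place of 2-chlorophenyl gives no change at the digits printed from compound 1 to compound 4 (within the scatter). Against 3-methoxyphenyl, 4-chlorophenyl gives a 2.0-fold higher number from compound 2 to compound 4 (0.30 log units; within the scatter), whereas against 2-methoxyphenyl it gives a 4.4-fold higher number from compound 3 to compound 4 (0.64 log units; beyond the scatter), so compound 3 alone stands apart from the other three. No measurement available here explains these differences. It remains open whether an amine or a carboxylic acid on this aryl ring would shift the number further than any group shown.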